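The source may report more compounds than this note shows. Statements on the series, on what has been measured and on what is new or still open speak of the compounds shown alone.

Measured so far:
compound 1, `c1cc(-c2nccs2)c2c(c1)C(c1ncc[nH]1)CC2`; in a functional assay on CHO cells for agonist activity at Alpha-1B adrenergic receptor (Homo sapiens), read by FLIPR and calcium flux (a lower number here means that less compound is needed, a higher number that more compound is needed for the effect), compound 1 gives > 10000 nM, a limit of the assay.
compound 2, `CCS(=O)(=O)Nc1cccc(Cc2c[nH]cn2)c1`; in this assay compound 2 gives > 10000 nM, again a limit.
compound 3, `c1ccc2c(c1)CCCC2c1ncc[nH]1`; in this assay compound 3 gives 791 nM.

Compound 1 therefore stands at the limit of > 10000 nM in this assay, at which 2 of the 3 values shown sit, with no number of its own. Compound 4, `c1cncc(-c2cccc3c2CCC3c2ncc[nH]2)c1`, differs from compound 1 only as pyridin-3-yl in place of 1,3-thiazol-2-yl on an aromatic carbon. For the measured compounds named here, no measured pair shows this change, so no size for the step is known; compound 3, which carries neither group, gives 791 nM, the one numeric value of the three. The step is expected to be small, likely within scatter: an at least 1.2-fold lower number from compound 1 to compound 4 (0.09 log units; that floor lies within the scatter). Compound 4 is estimated at 8000 nM, between 2000 nM and 30000 nM.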

Compound 4, half-maximal effective concentration: > 10000 nM
Compound 4: only a limit was reported; the forecaster's own chance of this, stated with the estimate: 55%; middle value at least 1.2-fold (0.09 log units) from the limit.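

No step can be read from compound 1 to compound 4, since both carry only a limit: the limit of > 10000 nM in this assay, at which 3 of the 4 values shown sit.

The compounds shown leave open whether pyridin-3-yl and 1,3-thiazol-2-yl differ at all on this aromatic carbon of the shared core.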